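The source may report more compounds than this note shows. Statements on the series, on what has been measured and on what is new or still open speak of the compounds shown alone.

Compound 1, `CO[C@H]1CC[C@H](NC(=O)c2n[nH]cc2NC(=O)c2ccccc2C(F)(F)F)CC1`, gives 3300 nM in an ADME assay on MRC5 cells (Homo sapiens) for inhibition, with a stated time of 72 h; a higher number here means that more compound is needed for the effect, a lower number that less compound is needed.
Compound 2, `CCc1ccccc1C(=O)Nc1c[nH]nc1C(=O)N[C@H]1CC[C@H](OC)CC1`, gives 3400 nM in this assay.
Compound 3, `COc1cccc(OC)c1C(=O)Nc1c[nH]nc1C(=O)NC1CCC1`, gives only a limit of the assay, > 50000 nM, in this assay.

Among the measured compounds shown here, compound 2 holds the higher of the two numbers that were actually obtained, yet its only neighbour, compound 1, sits within the scatter of it: a 1.0-fold higher number from compound 1 to compound 2 (0.01 log units; within the scatter). Compound 3 gives no number, only a limit (the limit of > 50000 nM in this assay, at which 1 of the 3 values shown sits), so its distance from compound 2 cannot be stated.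

Compound 4 is `CO[C@H]1CC[C@H](NC(=O)c2n[nH]cc2NC(=O)c2cc(F)cc(F)c2)CC1`. It differs from compound 2 in a single place: 3,5-difluorophenyl in place of 2-ethylphenyl on a carbonyl carbon. For the measured compounds named here, the one measured step exchanges a single group on the aromatic ring and leaves the number essentially unchanged, whereas here the whole ring is swapped for a differently substituted one, so no measured step covers the change directly. The fact that a differently substituted ring in compound 3 reached only a limit is a caution, but compound 3 also carries a different group at the other end of the core, so it does not isolate this change.

Going by the values given here, with no matching step, the expected step is a 1.8-fold higher number from compound 2 to compound 4 (0.25 log units; within the scatter), carried with a broad range. Compound 4 is therefore estimated at 6000 nM, between 1500 nM and 30000 nM.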

Compound 4, half-maximal effective concentration: 600 nM
For compound 4 the middle estimate is 10-fold (1.00 log units) above the measured one; the measured number lies below the stated range.
By their numbers in this assay, from the lowest: compound 4; then compounds 1 and 2 (each within the scatter of the next). At a limit, above all of these: compound 3.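

Swapping 2-ethylphenyl for 3,5-difluorophenyl on the carbonyl carbon gives a 5.7-fold lower number from compound 2 to compound 4 (0.75 log units; beyond the scatter) in this assay, which means that less compound is needed for the effect, and this is the first change among these compounds to move the number beyond the usual scatter. The earlier exchange on the aromatic ring, a 1.0-fold higher number from compound 1 to compound 2 (0.01 log units; within the scatter), could have suggested that this part of the molecule hardly affects the result, but compound 4 shows that the choice of ring substitution can matter even though the groups that leave and enter have the same heavy-atom count and neither carries a charge. Nothing measured here explains why the number moves.

Because compound 4 loses the ethyl group and gains two fluorines in a single step, the compounds shown cannot separate the effect of removing one from that of adding the other. Plain phenyl or a phenyl ring with only one fluorine would help to divide the change, while a phenyl ring carrying an amine or a carboxylic acid would test a quite different kind of group at this place.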